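Sec-butyl for 4-methylphenyl on the carbonyl carbon

This account rests on a few compounds, and the source may have more. Where it says the series, first, only, none or still open, it means among the compounds named here.

Of the compounds shown here, three on the shared core have numbers so far. In a physicochemical assay for solubility, read by HPLC (on this read-out lower numbers stand for lower solubility and higher numbers for higher solubility), compound 1 (`CSCC(=O)N1CCN(c2nc(=O)c3cc(C(F)(F)F)cc([N+](=O)[O-])c3s2)CC1`) gives 15.2 ug/mL, compound 2 (`O=C(c1ccccc1F)N1CCN(c2nc(=O)c3cc(C(F)(F)F)cc([N+](=O)[O-])c3s2)CC1`) gives 3.1 ug/mL and compound 3 (`Cc1ccc(C(=O)N2CCN(c3nc(=O)c4cc(C(F)(F)F)cc([N+](=O)[O-])c4s3)CC2)cc1`) gives 6.7 ug/mL. Compound 3 is therefore second highest of the three.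

Compound 4 (`CCC(C)C(=O)N1CCN(c2nc(=O)c3cc(C(F)(F)F)cc([N+](=O)[O-])c3s2)CC1`) has sec-butyl in place of 4-methylphenyl on a carbonyl carbon.

All measured steps concern this same carbonyl carbon. The change to 4-methylphenyl gave a 2.3-fold lower number from compound 1 to compound 3 (0.36 log units; beyond the scatter), the change to 2-fluorophenyl gave a 4.9-fold lower number from compound 1 to compound 2 (0.69 log units; beyond the scatter), and 4-methylphenyl in place of 2-fluorophenyl gave a 2.2-fold higher number from compound 2 to compound 3 (0.33 log units; beyond the scatter). All three are modest. Going by the values given here, no measured compound carries sec-butyl. Among the compounds with values here, compound 1, the only measured compound without a ring in this group, has the highest number at 15.2 ug/mL, so a modest upward step in this assay is expected, though this rests on one compound.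

The expected step is a 1.8-fold higher number from compound 3 to compound 4 (0.25 log units; within the scatter). For compound 4 the estimate is 12 ug/mL, with an expected range of 5 ug/mL to 28 ug/mL.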

Compound 4, solubility: 104 ug/mL
For compound 4 the middle estimate is 8.7-fold (0.94 log units) below the measured one, and the stated range ends below it.
By their numbers in this assay, from the lowest: compound 2; then compound 3; then compound 1; then compound 4.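

In this assay sec-butyl in place of 4-methylphenyl gives a 16-fold higher number from compound 3 to compound 4 (1.19 log units; beyond the scatter) and in place of 2-fluorophenyl gives a 34-fold higher number from compound 2 to compound 4 (1.53 log units; beyond the scatter) on the same carbonyl carbon, so this position spans a much wider range than the three earlier compounds showed. Both groups without a ring stand above both six-membered aromatic rings among these four compounds, yet sec-butyl in place of (methylsulfanyl)methyl still gives a 6.8-fold higher number from compound 1 to compound 4 (0.84 log units; beyond the scatter) and the absence of a ring therefore does not settle the number by itself. No evidence is available that bears on the size of this change.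

From the compounds shown here alone, whether the high number is particular to sec-butyl or extends to tert-butyl or a longer chain remains open. Also open, going by these compounds, is whether cyclohexyl, a ring without aromatic character, would sit with the two aryl compounds or with compound 4.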